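The source may report more compounds than this note shows. Statements on the series, on what has been measured and on what is new or still open speak of the compounds shown alone.

Compound 1 `CC(C)CN1CCCN(CCn2ccc3ccc(Br)cc32)CC1`: in an assay on HEK293 cells for binding affinity to 5-hydroxytryptamine receptor 7 (Homo sapiens), read by radioligand binding, tested at 1 uM (on this read-out lower numbers stand for less inhibition and higher numbers for more inhibition at the one concentration tested (going by the name of the read-out)), compound 1 gives 95%.
Compound 2 `Brc1ccc2ccn(CCN3CCCN(C4CCCC4)CC3)c2c1`: in this assay compound 2 gives 98%.
Compound 3 `Brc1ccc2ccn(CCN3CCCN(C4CCCCC4)CC3)c2c1`: in this assay compound 3 gives 96%.

All three share the same core and differ only in the group on the amine nitrogen of the seven-membered ring. Compound 3 stands in the middle of the three numbers, but the gaps on either side are small: the step of a number 1 percentage points higher from compound 1 to compound 3 (within the scatter) and the step of a number 2 percentage points lower from compound 2 to compound 3 (within the scatter) both lie within the usual scatter, so none of the three can be told apart on these data. The third step, a number 3 percentage points higher from compound 1 to compound 2 (within the scatter), is equally flat.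

Compound 4 `Brc1ccc2ccn(CCN3CCCN(c4ccccc4)CC3)c2c1` has not yet been measured in this assay. It differs from compound 3 by phenyl in place of cyclohexyl on an amine nitrogen in a ring. Among the compounds with values here, the steps that bear on this change are those that alter the same group on the same nitrogen: isobutyl to cyclopentyl, isobutyl to cyclohexyl and cyclopentyl to cyclohexyl, each of them within the scatter. None of them, however, exchanges a non-aromatic ring for an aromatic one, so the measured steps give no direct guide to phenyl. Because compound 3 gives 96%, compound 4 is expected to keep a high number, with a step of a number 6 percentage points lower from compound 3 to compound 4 (within the scatter) of no more than the scatter, though a somewhat larger drop cannot be excluded. Compound 4 is therefore estimated at 90%, in the range 72% to 99%.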

Compound 4, a percentage reported as inhibition, at one concentration (the size of the read-out at that concentration, not a potency): 18%
Beside the measured number, compound 4's estimate is 72 percentage points above it, outside the stated range (below it).
By their numbers in this assay, from the lowest: compound 4; then compounds 1, 3 and 2 (each within the scatter of the next).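

In this assay the isobutyl, cyclopentyl and cyclohexyl groups on the amine nitrogen could not be told apart, yet this position proves far from indifferent to the group it carries: the change to phenyl gives a number 78 percentage points lower from compound 3 to compound 4 (beyond the scatter) and also a number 80 percentage points lower from compound 2 to compound 4 (beyond the scatter) and likewise a number 77 percentage points lower from compound 1 to compound 4 (beyond the scatter) on the same core. The closest pair shows the sharpest contrast, since cyclohexyl and phenyl have the same count of six carbon atoms, with no hydrogen-bond donors or acceptors and no net charge on either, so that what the structures record as different is a non-aromatic ring against an aromatic one. Nothing among the available data accounts for this loss of inhibition at the one concentration tested.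

The compounds shown leave open whether the loss goes with any aromatic ring on this nitrogen or only with a phenyl ring bonded directly to it, which a benzyl group would address. They also leave open how a pyridyl ring or a methoxyphenyl group would read at this position.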